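Sulfonyl aryl series: 4-chlorophenyl to 4-bromophenyl

The compounds below may be only part of what the source reports. "The series", "measured", "known", "first", "only" and "open" are said of these compounds alone.

Measured in a functional assay on A549 cells (Homo sapiens) for antiproliferative activity, read by MTT assay, with a stated time of 24 h; a lower number here means a stronger inhibitor, a higher number a weaker inhibitor:
- compound 1 `O=S(=O)(c1ccccc1)n1c(-c2cn(-c3ccccc3)nc2-c2ccc(F)cc2)nc2ccccc21`: 550 nM
- compound 2 `Cc1ccc(C)c(S(=O)(=O)n2c(-c3cn(-c4ccccc4)nc3-c3ccc(F)cc3)nc3ccccc32)c1`: 200 nM
- compound 3 `O=S(=O)(c1ccc(Cl)cc1)n1c(-c2cn(-c3ccccc3)nc2-c2ccc(F)cc2)nc2ccccc21`: 3170 nM

Compound 3 has the highest number of the three and is the weakest inhibitor measured so far in this assay. Compound 4 `O=S(=O)(c1ccc(Br)cc1)n1c(-c2cn(-c3ccccc3)nc2-c2ccc(F)cc2)nc2ccccc21` carries bromo in place of chloro on an aromatic carbon, para to a large group (bromo in place of chloro on an aromatic carbon). The closest measured change is modest: a 5.8-fold higher number from compound 1 to compound 3 (0.76 log units; beyond the scatter), where chloro replaces hydrogen. A larger change, a 16-fold higher number from compound 2 to compound 3 (1.20 log units; beyond the scatter), exchanges the whole aryl group. Neither swaps one halogen for another, so the data suggest no direction, and no shift beyond the scatter is expected. The expected change is a 1.3-fold lower number from compound 3 to compound 4 (0.10 log units; within the scatter). For compound 4 the estimated value is 2500 nM, with an expected range of 900 nM to 6500 nM.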

Compound 4, half-maximal inhibitory concentration: 1720 nM
Compound 4: middle estimate off by 1.5-fold (0.16 log units), on the high side, and the stated range covers the measured number.
By their numbers in this assay, from the lowest: compound 2; then compound 1; then compounds 4 and 3 (each within the scatter of the next).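

In this assay the halogen swap gives a 1.8-fold lower number from compound 3 to compound 4 (0.27 log units; within the scatter) and so does not separate chloro from bromo at this position. Bromo in place of hydrogen gives a 3.1-fold higher number from compound 1 to compound 4 (0.50 log units; beyond the scatter) in the same direction as the chloro step, so both halogens read apart from the unsubstituted phenyl. The 2,5-dimethylphenyl group also reads apart from 4-bromophenyl, with an 8.6-fold higher number from compound 2 to compound 4 (0.93 log units; beyond the scatter) on that exchange.

Open, from the compounds shown here alone, is whether fluoro, methoxy or an amine at this position would follow the halogens, and which methyl group of compound 2 matters. No evidence bears on the cause of these steps.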